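The source may report more compounds than this note shows. Statements on the series, on what has been measured and on what is new or still open speak of the compounds shown alone.

Compound 2 `C=CCCCCCCCCCCCC(O)CC(O)CO` is a long chain carrying three hydroxyl groups at one end and a vinyl group at the other. For the measured compounds named here, in a functional assay on MIA PaCa-2 cells (Homo sapiens) for cytotoxicity, read by MTT assay (a higher number here means a weaker inhibitor, a lower number a stronger inhibitor), compound 2 gives 5.3 ug/mL, the only plain number among the values shown. Compound 1 `CCCCCCCCCCCCCCCC(O)CC(O)CO` has the same chain without the vinyl group. In this assay compound 1 reaches only the limit of the assay, > 10 ug/mL, so it has no number of its own (the limit of > 10 ug/mL in this assay, at which 1 of the 2 values shown sits). Going by the values given here, the step of an at least 1.8-fold lower number from compound 1 to compound 2 (0.27 log units; that floor lies within the scatter) is the single measured comparison, and since its floor lies within the usual scatter, it cannot show whether the vinyl group changes the result at all. Compound 3 `C#CCCCCCCCCCCCC(O)CC(O)CO` is not yet measured. It differs from compound 2 by ethynyl in place of vinyl on a saturated chain carbon, ten or more bonds along the chain from an oxygen on a saturated carbon. Among the compounds with values here, no measured step touches this particular swap, and it is a smaller change than the one from compound 1 to compound 2. The step of a 1.1-fold lower number from compound 2 to compound 3 (0.03 log units; within the scatter) is therefore expected to stay within the scatter, in no settled direction. Compound 3 is estimated to give about 5 ug/mL in this assay, with a likely range from 2.5 ug/mL to 10 ug/mL.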

Compound 3, half-maximal inhibitory concentration: > 10 ug/mL
Compound 3 gave a limit, no number (the forecaster's own chance of this, stated with the estimate: 20%); middle value at least 2.0-fold (0.30 log units) away from the limit.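

Compound 2 now stands with a limit on both sides, since the change from vinyl to ethynyl on a saturated chain carbon gives an at least 1.8-fold higher number from compound 2 to compound 3 (0.27 log units; that floor lies within the scatter) in this assay. A double bond and a triple bond at this place, with the same count of heavy atoms, therefore need not read alike, but the floor of this step is too small to show that the swap changes the result at all. The step between compound 1 and compound 3 cannot be read, and a single plain number gives this small set little to compare: the limit of > 10 ug/mL in this assay, at which 2 of the 3 values shown sit.

On these data alone, how far compound 3 really lies from compound 2 stays open, since compound 3 has only a limit and no number of its own. Also open, as far as these compounds go, is what a nitrile, an amine or a carboxylic acid would give in this assay in place of vinyl at this same place, and whether such a group would yield a plain number.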